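The compounds below may be only part of what the source reports. "The series", "measured", "known", "first", "only" and "open" are said of these compounds alone.

Measured in an ADME assay on HepG2 cells (Homo sapiens) for cytotoxicity, read by MTT assay, with a stated time of 72 h; a higher number here means a weaker inhibitor, a lower number a stronger inhibitor:
- compound 1 `O=C(Oc1ccc(Br)cc1C(=O)Nc1ccc(C(F)(F)F)cc1)c1ccc(Br)cc1`: > 50000 nM (a limit)
- compound 2 `Cc1ccc(C(=O)Oc2ccc(Cl)cc2C(=O)Nc2ccc(Cl)c(Cl)c2)cc1`: > 50000 nM (a limit)
- compound 3 `Cc1ccc(C(=O)Oc2ccc(Cl)cc2C(=O)Nc2ccc(C(F)(F)F)cc2)cc1`: > 50000 nM (a limit)

These three results share one feature: the limit of > 50000 nM in this assay, at which 3 of the 3 values shown sit. None of them is a true number, so the compounds cannot be ranked against each other. Compound 3 therefore stands at the limit, with > 50000 nM as its only result.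

Compound 4 `O=C(Oc1ccc(Cl)cc1C(=O)Nc1ccc(C(F)(F)F)cc1)c1ccc(Br)cc1` differs from compound 3 in one place: bromo in place of methyl on an aromatic carbon. This puts bromo in place of methyl on an aromatic carbon, para to a large group, turning 4-methylphenyl into 4-bromophenyl.

Among the measured compounds shown here, no measured step covers this exchange. For the measured compounds named here, the only one available is a step that the two limits leave unreadable from compound 2 to compound 3, and it concerns the group on an amide-type nitrogen, so it gives only indirect guidance. Compound 1 is more relevant, since it also carries the 4-bromophenyl group. Compound 1 gives > 50000 nM, which is again a limit.

On this basis, no change beyond the usual scatter is expected in this assay, in either direction. The estimated change is a number no higher from compound 3 to compound 4 (the limit leaves the size open). A report of a limit is the most likely outcome. For compound 4 the expected value is 50000 nM. The estimated range for compound 4 runs from 25000 nM to 100000 nM.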

Compound 4, half-maximal inhibitory concentration: > 50000 nM
Compound 4: no number, only a limit (the forecaster's own chance of this, stated with the estimate: 85%); the middle value lies on the limit itself.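

In this assay compound 4 gives > 50000 nM, which is a limit and not a number. The steps to compound 4 from compound 3 and from compound 1 therefore cannot be read: the limit of > 50000 nM in this assay, at which 4 of the 4 values shown sit.

The compounds shown leave open whether any of these exchanges of groups changes the result in this assay.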